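Adding a Second Methoxy to Compound 2

The compounds below may be only part of what the source reports. "The series", "measured", "known", "first", "only" and "open" are said of these compounds alone.

In a functional assay on HeLa cells (Homo sapiens) for antiproliferative activity, with a stated time of 48 h (a lower number here means a stronger inhibitor, a higher number a weaker inhibitor), compound 1 `C=C(Br)C(=O)Nc1ccc(C(=O)/C=C/c2ccc(OC)cc2)cc1` gives 310 nM and compound 2 `C=C(Br)C(=O)Nc1ccc(C(=O)/C=C/c2ccccc2OC)cc1` gives 1300 nM, the higher of the two numbers. Compound 3 `C=C(Br)C(=O)Nc1ccc(C(=O)/C=C/c2ccc(OC)cc2OC)cc1` differs from compound 2 by methoxy in place of hydrogen on an aromatic carbon, para to a large group and meta to a methoxy group. Among the measured compounds shown here, one measured step bears on this, the modest 4.2-fold higher number from compound 1 to compound 2 (0.62 log units; beyond the scatter), beyond the scatter, with 2-methoxyphenyl in place of 4-methoxyphenyl. Compound 3 carries both methoxy placements, so a modest fall is expected, namely a 2.2-fold lower number from compound 2 to compound 3 (0.34 log units; beyond the scatter). For compound 3 the estimated value is 600 nM, within a range of 220 nM to 1500 nM.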

Compound 3, half-maximal inhibitory concentration: 1100 nM
Compound 3: middle estimate off by 1.8-fold (0.26 log units), on the low side, within the range that was stated.
By their numbers in this assay, from the lowest: compound 1; then compounds 3 and 2 (each within the scatter of the next).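

In this assay, methoxy in place of hydrogen, para to a large group and meta to a methoxy group, does not separate the two compounds (a 1.2-fold lower number from compound 2 to compound 3 (0.07 log units; within the scatter)), so this position accepts the group on compound 2 with no change beyond the scatter. Compound 3 still stands apart from compound 1 (a 3.5-fold higher number from compound 1 to compound 3 (0.55 log units; beyond the scatter)), so the 4-methoxy pattern of compound 1 does not keep its lower number once the other methoxy is present. No available evidence explains this result. As far as these compounds go, whether a hydroxyl, an amine or a longer chain at this position would behave like methoxy remains open.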